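The compounds below may be only part of what the source reports. "The series", "measured", "known", "first", "only" and "open" are said of these compounds alone.

For the measured compounds named here, in a functional assay on OVCAR-3 cells (Homo sapiens) for inhibition, read by MTT assay, with a stated time of 24 h (on this read-out lower numbers stand for stronger inhibition and higher numbers for weaker inhibition), compound 1 `COc1ccccc1-n1cc(CN2C(=O)C[C@@H]3CC[C@@]2(C)C3(C)C)nn1` gives 140 nM and compound 2 `CC1(C)[C@H]2CC[C@]1(C)N(Cc1cn(-c3ccc(O)cc3)nn1)C(=O)C2` gives 410 nM as the higher, and so weaker, of the two numbers so far. Going by the values given here, compound 3 `CC1(C)[C@H]2CC[C@]1(C)N(Cc1cn(-c3cccc(O)c3)nn1)C(=O)C2` has the same atoms joined differently, with 3-hydroxyphenyl in place of 4-hydroxyphenyl on an aromatic nitrogen as the only change. Among the compounds with values here, one measured step bears on this, the modest 2.9-fold higher number from compound 1 to compound 2 (0.47 log units; beyond the scatter) seen when the group on that same aromatic nitrogen was changed. That step involves a different pair of groups, so it sets no clear direction here. Only a small change is expected, a 1.2-fold lower number from compound 2 to compound 3 (0.07 log units; within the scatter) in this estimate. Compound 3 is estimated at 350 nM with an expected range from 130 nM to 900 nM overall.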

Compound 3, half-maximal inhibitory concentration: 370 nM
Compound 3: middle estimate off by 1.1-fold (0.02 log units), on the low side; the range from low to high includes it.
By their numbers in this assay, from the lowest: compound 1; then compounds 3 and 2 (each within the scatter of the next).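

With 3-hydroxyphenyl in place of 4-hydroxyphenyl, this assay shows a 1.1-fold lower number from compound 2 to compound 3 (0.04 log units; within the scatter), so this assay does not separate these two placements of the hydroxyl group. The 2-methoxyphenyl comparison also holds for the new compound, with a 2.6-fold higher number from compound 1 to compound 3 (0.42 log units; beyond the scatter), so both hydroxyphenyl compounds give higher numbers than compound 1. No measurement available here explains these results. As far as these compounds go, it remains open whether the gap to compound 1 follows the methoxy group or its place on the phenyl ring, which 2-hydroxyphenyl and 3-methoxyphenyl would separate. From the compounds shown here alone, how an amine or a carboxylic acid on that phenyl ring would read is also open.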